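The source may hold more compounds than are shown below. What is called first, only, known or untested is meant among the compounds shown, and "the series" means these compounds.

Measured in a functional assay on HEK293 cells (Homo sapiens) for cytotoxicity (a lower number here means that less compound is tolerated, a higher number that more compound is tolerated), so far, each value being a limit of the assay and not a number:
- Compound 1 `COc1ccc([C@H]2CC(=O)N(Cc3cccc(C#N)c3)C2)cc1OC1CCCC1` gives > 10000 nM as its limit
- Compound 2 `COc1ccc([C@H]2CC(=O)N(c3ccc(N)cc3)C2)cc1OC1CCCC1` gives > 10000 nM as its limit
- Compound 3 `COc1ccc([C@H]2CC(=O)N(c3ccccc3C#N)C2)cc1OC1CCCC1` gives > 10000 nM as its limit

Compound 3 stands with the other two at the limit of > 10000 nM in this assay, at which 3 of the 3 values shown sit, and has no number of its own. Compound 4 `COc1ccc([C@H]2CC(=O)N(c3ccccc3C)C2)cc1OC1CCCC1` carries methyl in place of cyano on an aromatic carbon, ortho to a large group (methyl in place of cyano on an aromatic carbon). The measured steps (a step that the two limits leave unreadable from compound 1 to compound 2 and a step that the two limits leave unreadable from compound 1 to compound 3 and a step that the two limits leave unreadable from compound 2 to compound 3) all concern the group on the amide-type nitrogen in a ring, and none has a readable size. With compound 3 at the limit of > 10000 nM in this assay, at which 3 of the 3 values shown sit, no step beyond the scatter is expected in this assay in either direction. The estimated step is a step that the limit leaves unreadable from compound 3 to compound 4 and carries no claim of change. For compound 4 the expected value is 15000 nM with an estimated range from 7000 nM to 40000 nM and a limit is the likeliest report.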

Compound 4, half-maximal cytotoxic concentration: > 10000 nM
Compound 4: a limit, no number (the forecaster's own chance of this, stated with the estimate: 85%); the middle value does not contradict the limit.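

In this assay, among the compounds shown here, no step from compound 1, compound 2 or compound 3 to compound 4 can be read, because all four compounds rest on a limit and not a number: the limit of > 10000 nM in this assay, at which 4 of the 4 values shown sit. The compounds shown leave open at what concentration any of them turns cytotoxic, and whether the groups that differ among them change that concentration at all.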